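Swapping methoxy for bromo on the shared core

A few compounds are considered here, and "the series" means these few. Any claim that something is new, unique, unknown or untested is made for them only; others in the source may bear on it.

Compound 1 `COc1ccc2c(c1)c(-c1nc3ccccc3n1C(=O)c1ccccc1Br)cn2C` gives 29500 nM in a functional assay on A549 cells (Homo sapiens) for inhibition, read by MTT assay, with a stated time of 24 h; a higher number here means a weaker inhibitor of growth, a lower number a stronger inhibitor of growth
Compound 2 `COc1ccc2c(c1)c(-c1nc3ccccc3n1C(=O)c1cccc(Br)c1)cn2C` gives 24800 nM in this assay

Within the data shown here, compound 1 and compound 2 lie within the scatter of each other, so these two numbers cannot be ranked, and compound 1 simply stands level with its only neighbour.

Compound 3 `Cn1cc(-c2nc3ccccc3n2C(=O)c2ccccc2Br)c2cc(Br)ccc21` keeps the 2-bromophenyl group of compound 1 and differs in one place: bromo in place of methoxy on an aromatic carbon. In short, it has bromo in place of methoxy on an aromatic carbon.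

Among the measured compounds shown here, only one measured step exists, a 1.2-fold lower number from compound 1 to compound 2 (0.08 log units; within the scatter), and it concerns a different place, the group on the carbonyl carbon. It shows that one change there made no clear difference, but it says nothing direct about losing methoxy. For the measured compounds named here, no measured pair tests that swap, so the data favour no direction.

The expected outcome is therefore no step beyond the scatter, and the estimated change is a 1.1-fold lower number from compound 1 to compound 3 (0.04 log units; within the scatter), a figure held loosely. For compound 3 the estimate is 27000 nM, with an expected range from 11000 nM to 65000 nM in this assay.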

Compound 3, concentration for 50% growth inhibition: 46700 nM
Compound 3: middle estimate off by 1.7-fold (0.24 log units), on the low side, and the stated range covers the measured number.
By their numbers in this assay, from the lowest: compounds 2, 1 and 3 (each within the scatter of the next).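

Among these compounds, the step of a 1.6-fold higher number from compound 1 to compound 3 (0.20 log units; within the scatter) in this assay gives the first reading at this position, for bromo in place of methoxy on an aromatic carbon with the 2-bromophenyl group held fixed. A change on the shared core has now been read, alongside the earlier change on the carbonyl carbon, and this one also stays within the scatter, so compound 1 and compound 3 cannot be ranked. This single swap gives no sign that methoxy is needed at this place or that bromo serves any better, and no measured evidence is at hand to explain the result.

The compounds shown leave open whether a different kind of group at this place, such as an amine, a carboxylic acid or a longer chain like propoxy, would give a step beyond the scatter. They also leave open whether bromo in place of methoxy would read the same on compound 2, which carries the 3-bromophenyl group on the carbonyl carbon.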